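A few compounds are considered here, and "the series" means these few. Any claim that something is new, unique, unknown or untested is made for them only; others in the source may bear on it.

Measured compounds in the series:

Compound 1, `CCO/C(O)=C1\C(COCCn2ccnn2)=NC(C)=C(C(=O)OC)C1c1cccc(Cl)c1Cl`: 5.01 nM
Compound 2, `CCO/C(O)=C1\C(COCCn2c(C)nc(C)c2C)=NC(C)=C(C(=O)OC)C1c1ccccc1Cl`: 5.01 nM
Compound 3, `CCOC(=O)c1cnnn1CCOCC1=NC(C)=C(C(=O)OC)C(c2ccccc2Cl)/C1=C(\O)OCC`: 100 nM

All three were tested in a functional assay (aorta) with Rattus norvegicus as the target; on this read-out lower numbers stand for stronger inhibition and higher numbers for weaker inhibition. Compound 3 carries the highest number of the three; its nearest neighbour on the read-out is compound 1, and the gap to compound 2 is given by a 20-fold higher number from compound 2 to compound 3 (1.30 log units; beyond the scatter), a large step that comes with exchanging the whole 2,4,5-trimethyl-1H-imidazol-1-yl for 5-(ethoxycarbonyl)-1H-1,2,3-triazol-1-yl on the saturated chain carbon two bonds along from the chain oxygen.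

Compound 4, `CCO/C(O)=C1\C(COCCn2nncc2C(N)=O)=NC(C)=C(C(=O)OC)C1c1ccccc1Cl`, keeps that triazole and alters only its substituent: amino in place of ethoxy on a carbonyl carbon. Within the data shown here, no measured step in this set touches the group on the carbonyl carbon; the only comparison available, the step from compound 2 to compound 3, changes a different part of the molecule and so does not speak to an ester-to-amide exchange. Compound 3 is therefore the sole anchor, and the step I estimate for compound 4 is a 1.3-fold lower number from compound 3 to compound 4 (0.10 log units; within the scatter), an expected change whose size is uncertain and for which no direction beyond the scatter is assumed. For compound 4 the expected value in this assay is 80 nM, estimated to lie between 20 nM and 320 nM.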

Compound 4, half-maximal inhibitory concentration: 100 nM
Compound 4: the middle estimate sits 1.3-fold (0.10 log units) below what was measured, within the range that was stated.
By their numbers in this assay, from the lowest: compounds 1 and 2 (each within the scatter of the next); then compounds 3 and 4 (each within the scatter of the next).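

In this assay the exchange of ethoxy for amino on a carbonyl carbon gives no change at the digits printed from compound 3 to compound 4 (within the scatter) and so does not separate 5-(ethoxycarbonyl)-1H-1,2,3-triazol-1-yl from 5-carbamoyl-1H-1,2,3-triazol-1-yl at this position. The gap to the 2,4,5-trimethyl-1H-imidazol-1-yl compound remains with the carbamoyl group: that exchange gives a 20-fold higher number from compound 2 to compound 4 (1.30 log units; beyond the scatter) and is therefore not confined to the ethoxycarbonyl compound. No evidence on the reason for either result is available.

Going by these compounds, whether a carboxylic acid or an N-methyl amide on this carbonyl carbon would read the same as ethoxy and amino remains open. Also open, on these data alone, is whether the ethoxy-to-amino exchange stays flat with a longer chain between the oxygen and the triazole.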